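Losing a naphthalene ring from compound 2

This account rests on a few compounds, and the source may have more. Where it says the series, first, only, none or still open, it means among the compounds named here.

Compound 1 `CC1OC2(C=CC(=O)C=C2)N(c2nc(-c3ccc4ccccc4c3)nn2-c2ccc3ccccc3c2)C1=O`: 60 nM
Compound 2 `O=C1C=CC2(C=C1)OCC(=O)N2c1nc(-c2ccc3ccccc3c2)nn1-c1ccc2ccccc2c1`: 50 nM

For the measured compounds named here, in a functional assay on MDA-MB-231 cells (Homo sapiens) for antiproliferative activity, with a stated time of 5 days (on this read-out lower numbers stand for stronger inhibition and higher numbers for weaker inhibition), compound 2 stands level with compound 1, the only other compound measured: a 1.2-fold lower number from compound 1 to compound 2 (0.08 log units; within the scatter). Compound 3 `O=C1C=CC2(C=C1)OCC(=O)N2c1nc(-c2ccc3ccccc3c2)nn1-c1ccccc1` keeps the shared core but has phenyl in place of naphthalen-2-yl on an aromatic nitrogen. Going by the values given here, the one measured step concerns hydrogen in place of methyl on a saturated ring carbon, so no measurement tests this change directly. The expectation rests on the structural change alone, and a moderate move to a higher number in this assay is expected, held loosely. The expected step is a 3.0-fold higher number from compound 2 to compound 3 (0.48 log units; beyond the scatter). Compound 3 is estimated at 150 nM, with an expected range of 50 nM to 600 nM.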

Compound 3, half-maximal inhibitory concentration: 70 nM
For compound 3 the middle estimate is 2.1-fold (0.33 log units) above the measured one; the range from low to high includes it.
By their numbers in this assay, from the lowest: compounds 2, 1 and 3 (each within the scatter of the next).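

In this assay, phenyl in place of naphthalen-2-yl on an aromatic nitrogen gives a 1.4-fold higher number from compound 2 to compound 3 (0.15 log units; within the scatter), so one of the two six-membered aromatic rings at this position can go without a step beyond the scatter. For the compounds shown here, the earlier step concerned only a saturated ring carbon, so this is the first reading at this position. No evidence is available to account for this result.

Still open, on these data alone, is whether a phenyl carrying an amine or a carboxylic acid, or a plain methyl, would hold this level here. Whether the second naphthalen-2-yl group can also become phenyl is open too.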